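A few compounds are considered here, and "the series" means these few. Any claim that something is new, unique, unknown or untested is made for them only; others in the source may bear on it.

Compound 1 `Cc1nn(C)c(Oc2cccc(F)c2F)c1/C=N\CCCCCCOc1cc2oc(=O)cc(C)c2cc1Cl`: in a functional assay on U-87MG ATCC cells for antiproliferative activity against U-87 MG (Homo sapiens), read by MTT assay, with a stated time of 72 h (on this read-out higher numbers stand for weaker inhibition and lower numbers for stronger inhibition), compound 1 gives > 25000 nM, which is a limit of the assay rather than a number.
Compound 2 `Cc1nn(C)c(Oc2ccc(F)cc2F)c1/C=N\CCCCCCOc1cc2oc(=O)cc(C)c2cc1Cl`: compound 2 gives > 25000 nM, again a limit.
Compound 3 `Cc1nn(C)c(Oc2ccccc2Br)c1/C=N\CCCCCCOc1cc2oc(=O)cc(C)c2cc1Cl`: compound 3 gives 21800 nM.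

Among the compounds with values here, compound 3 therefore holds the only actual number among the three; the other two values sit at the limit of > 25000 nM in this assay, at which 2 of the 3 values shown sit. Compound 4 `Cc1nn(C)c(Oc2cccc(Br)c2)c1/C=N\CCCCCCOc1cc2oc(=O)cc(C)c2cc1Cl` differs from compound 3 by 3-bromophenyl in place of 2-bromophenyl on an oxygen on an aromatic ring. The measured steps that touch this ring are an at least 1.1-fold lower number from compound 1 to compound 3 (0.05 log units; that floor lies within the scatter) and an at least 1.1-fold lower number from compound 2 to compound 3 (0.05 log units; that floor lies within the scatter), both floors that lie within the scatter, and neither involves rearranging a bromine on the same ring, so no guide exists for this change. The expectation is no step beyond the scatter, a 1.0-fold higher number from compound 3 to compound 4 (0.00 log units; within the scatter). Compound 4 is thus estimated at 22000 nM, with a range from 9000 nM to 40000 nM.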

Compound 4, half-maximal inhibitory concentration: 3610 nM
Compound 4: middle estimate off by 6.1-fold (0.78 log units), on the high side; measured number below the stated range.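

Moving the bromine, with the same atoms joined differently, matters at this position on the oxygen: a 6.0-fold lower number from compound 3 to compound 4 (0.78 log units; beyond the scatter). Against the difluorophenyl groups, the 3-bromophenyl group gives an at least 6.9-fold lower number from compound 2 to compound 4 (0.84 log units; beyond the scatter) and an at least 6.9-fold lower number from compound 1 to compound 4 (0.84 log units; beyond the scatter). These last two steps are only floors, as compound 1 and compound 2 each give a limit of the assay and not a number: the limit of > 25000 nM in this assay, at which 2 of the 4 values shown sit.

On these data alone, whether chlorine, a methoxy group or a nitrile in place of the bromine on the 3-bromophenyl group would keep this stronger inhibition stays open. So does the effect of a shorter chain in compound 4.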